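Triazole substituent variation and cytotoxicity in the series

The source may hold more compounds than are shown below. What is called first, only, known or untested is meant among the compounds shown, and "the series" means these compounds.

Compound 3 `Cc1cc(C)c(Oc2cc(Nc3ccc(C#N)cc3)ncc2C(=O)NCc2cn(Cc3ccc(F)cc3)nn2)c(C)c1` stands at a limit of an ADME assay on MT4 cells (Homo sapiens) for cytotoxicity, read by MTT assay, with a stated time of 5 days; on this read-out lower numbers stand for higher toxicity in this test and higher numbers for lower toxicity in this test: its value of >= 153000 nM is a limit rather than a number, and one further compound in the set is also reported only as a limit. Compound 1 `Cc1cccc(Cn2cc(CNC(=O)c3cnc(Nc4ccc(C#N)cc4)cc3Oc3c(C)cc(C)cc3C)nn2)c1` gives 114000 nM in this assay. Compound 2 `Cc1cc(C)c(Oc2cc(Nc3ccc(C#N)cc3)ncc2C(=O)NCc2cn(Cc3cccc(F)c3)nn2)c(C)c1` is read only as a limit, >= 204000 nM. The step of an at least 1.3-fold higher number from compound 1 to compound 3 (0.12 log units; that floor lies within the scatter) and the step of an at least 1.7-fold higher number from compound 1 to compound 2 (0.25 log units; that floor lies within the scatter) both lie within the scatter, and the step that the two limits leave unreadable from compound 2 to compound 3 cannot be read. Compound 4 `Cc1cc(C)c(Oc2cc(Nc3ccc(C#N)cc3)ncc2C(=O)NCc2cn(Cc3cccc([N+](=O)[O-])c3)nn2)c(C)c1` differs from compound 3 by 3-nitrophenyl in place of 4-fluorophenyl on a saturated chain carbon bound to an aromatic nitrogen. For the measured compounds named here, no measured step covers this change directly; the changes measured so far on the saturated chain carbon bound to an aromatic nitrogen moved the number by no more than the scatter, so no shift beyond the scatter is expected in this assay, and another limit is quite possible. For compound 4 the expected value is 150000 nM, between 75000 nM and 300000 nM, a step of an at least 1.0-fold lower number from compound 3 to compound 4 (0.00 log units; that floor lies within the scatter).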

Compound 4, half-maximal cytotoxic concentration: >= 156000 nM
Compound 4: a limit, no number; the forecaster's own chance of this, stated with the estimate: 60%; middle value at least 1.0-fold (0.01 log units) away from the limit.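

In this assay compound 4 is also reported only as a limit, so a nitro group joins fluoro on the benzyl ring at this position: the limit of >= 156000 nM in this assay, at which 1 of the 4 values shown sits. The series shows an at least 1.3-fold higher number from compound 1 to compound 4 (0.13 log units; that floor lies within the scatter) and the steps among the three limits cannot be read. On the saturated chain carbon bound to an aromatic nitrogen, 3-nitrobenzyl therefore adds no readable step beyond the scatter.

Open, as far as these compounds go, is whether an amine or a carboxylic acid on the benzyl ring, or a longer chain in place of benzyl, would give a clearly lower number in this assay. Any order among compound 2, compound 3 and compound 4 also stays unsettled.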